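Chloro to Cyano on a Growth-Inhibiting Amide

The source may report more compounds than this note shows. Statements on the series, on what has been measured and on what is new or still open speak of the compounds shown alone.

Measured so far in a functional assay on A549 cells (Homo sapiens) for inhibition, read by CCK-8 assay, with a stated time of 72 h, tested at 10 uM; on this read-out lower numbers stand for less inhibition of growth and higher numbers for more inhibition of growth at the one concentration tested:

- Compound 1 `CN(C)C(=O)c1cc2cnc(Nc3ccc(NC(=O)C4(C(=O)Nc5ccc(F)cc5)CC4)cc3)nc2n1C1CCCC1` gives 102%
- Compound 2 `COC(=O)c1ccc(NC(=O)C2(C(=O)Nc3ccc(Nc4ncc5cc(C(=O)N(C)C)n(C6CCCC6)c5n4)cc3)CC2)cc1` gives 92%
- Compound 3 `CN(C)C(=O)c1cc2cnc(Nc3ccc(NC(=O)C4(C(=O)Nc5cccc(Cl)c5)CC4)cc3)nc2n1C1CCCC1` gives 90.7%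

These three compounds share one core and differ only in the aromatic group on an amide-type nitrogen. Compound 3 stands level with compound 2, as the comparison shows: a number 1.3 percentage points lower from compound 2 to compound 3 (within the scatter). Against compound 1 the picture is a number 11.3 percentage points lower from compound 1 to compound 3 (beyond the scatter).

The next compound to be tested is compound 4 `CN(C)C(=O)c1cc2cnc(Nc3ccc(NC(=O)C4(C(=O)Nc5cccc(C#N)c5)CC4)cc3)nc2n1C1CCCC1`. It turns 3-chlorophenyl into 3-cyanophenyl, with cyano in place of chloro on an aromatic carbon, meta to a large group: cyano in place of chloro on an aromatic carbon.

Among the measured compounds shown here, no measured compound carries a cyano group, so the data offer no direct precedent. The closest guide is the set of changes already made on this same aromatic group. Besides the two steps above, there is a number 10 percentage points lower from compound 1 to compound 2 (within the scatter). Only one of these three lies beyond the scatter, and it is modest. In this assay a similar small shift is therefore expected, with no step beyond the scatter in either direction.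

The estimated change is a number 2.7 percentage points lower from compound 3 to compound 4 (within the scatter) for this swap. Compound 4 is expected to give 88%, with an estimated range from 72% to 101% overall.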

Compound 4, percent growth inhibition at one concentration: 73.6%
Beside the measured number, compound 4's estimate is 14.4 percentage points above it; the measured number falls inside the stated range.
By their numbers in this assay, from the lowest: compound 4; then compounds 3, 2 and 1 (each within the scatter of the next, the first and the last beyond it).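

In this assay, compounds 2 and 3 could not be told apart although their aromatic groups differ, which might suggest that this part of the molecule accepts change freely; compound 4 shows that this freedom has limits (a number 17.1 percentage points lower from compound 3 to compound 4 (beyond the scatter)). Only the group on the aromatic carbon changes in that step, chloro leaving and cyano entering at the same place, so the identity of this small group matters and not just its location on the ring. Compound 4 also sits clearly apart from the other two (a number 18.4 percentage points lower from compound 2 to compound 4 (beyond the scatter) and a number 28.4 percentage points lower from compound 1 to compound 4 (beyond the scatter)), which makes it the lowest of the four in this set, and nothing shown here explains the drop.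

From the compounds shown here alone, whether other small groups at this same place, such as methoxy, an amine or a carboxylic acid, would stay close to chloro or fall with cyano remains open. So does whether cyano would give a similar drop in the place held by fluoro in compound 1, since a single swap cannot show how far this result extends.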